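The compounds below may be only part of what the source reports. "The series", "measured", "known", "first", "only" and "open" are said of these compounds alone.

Measured so far in an assay on isolated protein for agonist activity at Alpha-2B adrenergic receptor (Homo sapiens); on this read-out lower numbers stand for an effect already at smaller amounts and higher numbers for an effect only at larger amounts of compound:
- compound 1 `C=CCc1ccccc1OCC1=NCCN1`: 977 nM
- compound 2 `c1ccc(OC2CC2)c(OCC2=NCCN2)c1`: 3160 nM
- compound 3 `CCCc1ccccc1OC(C)C1=NCCN1`: 5010 nM

Compound 3 carries the highest of the three numbers in this assay, yet its gap to compound 2 is within the scatter, so the two cannot be set apart; only compound 1 stands clearly below it. The unmeasured compound 4 `CCCc1ccccc1OCC1=NCCN1` arises from compound 3 by the change (hydrogen in place of methyl on a saturated chain carbon bound to a carbon with a double bond to nitrogen and an oxygen on an aromatic ring). Going by the values given here, the single measured step, a 3.2-fold higher number from compound 1 to compound 2 (0.51 log units; beyond the scatter), concerns an exchange of groups on the aromatic carbon and says nothing about the chain carbon that bears the methyl, so no measured step bears directly on this change. Compound 4 shares its unsubstituted linker with compound 1 and compound 2, and on that ground the expectation is a modest move toward their numbers, with a 3.3-fold lower number from compound 3 to compound 4 (0.52 log units; beyond the scatter) expected from compound 3 to compound 4. Compound 4 is therefore estimated at 1500 nM in this assay, within a range of 500 nM to 5000 nM.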

Compound 4, half-maximal effective concentration: 2510 nM
Compound 4: middle estimate off by 1.7-fold (0.22 log units), on the low side; the range from low to high includes it.
By their numbers in this assay, from the lowest: compound 1; then compounds 4, 2 and 3 (each within the scatter of the next).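

In this assay, hydrogen in place of methyl on a saturated chain carbon bound to a carbon with a double bond to nitrogen and an oxygen on an aromatic ring gives a 2.0-fold lower number from compound 3 to compound 4 (0.30 log units; within the scatter), so on this read-out the methyl at this position cannot be told apart from hydrogen. Among compounds with hydrogen at that carbon, propyl in place of cyclopropyloxy on an aromatic carbon gives a 1.3-fold lower number from compound 2 to compound 4 (0.10 log units; within the scatter), which also cannot be separated, while ethyl in place of vinyl on a saturated chain carbon bound to an aromatic carbon gives a 2.6-fold higher number from compound 1 to compound 4 (0.41 log units; beyond the scatter), the only one of these three steps beyond the scatter. No evidence at hand accounts for these numbers.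

The compounds shown leave open what a hydroxyl or an ethyl would do on the saturated chain carbon. They also leave open how an amine or a longer chain would read on the aromatic carbon.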